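The source may report more compounds than this note shows. Statements on the series, on what has been measured and on what is new or still open speak of the compounds shown alone.

In a functional assay on PC-3 cells (Homo sapiens) for inhibition, read by MTT assay, with a stated time of 48 h (on this read-out higher numbers stand for weaker inhibition of growth and lower numbers for stronger inhibition of growth), compound 1 `CN1CC[C@H](c2c(O)cc(O)c3c(=O)cc(/C=C/c4ccccc4)oc23)[C@H](O)C1` gives 58000 nM and compound 2 `CN1CC[C@H](c2c(O)cc(O)c3c(=O)cc(/C=C/c4ccc(Cl)cc4)oc23)[C@H](O)C1` gives 31000 nM. Going by the values given here, these are the only two numbers available, and they lie within the scatter of each other, so compound 2 stands level with compound 1. Compound 3 `CN1CC[C@H](c2c(O)cc(O)c3c(=O)cc(/C=C/c4cccc(Cl)c4)oc23)[C@H](O)C1` has the same atoms as compound 2, joined differently: 3-chlorophenyl in place of 4-chlorophenyl on a double-bonded chain carbon bound to a double-bonded chain carbon. It carries 3-chlorophenyl in place of 4-chlorophenyl on a double-bonded chain carbon bound to a double-bonded chain carbon. Among the compounds with values here, no measured pair shows this exchange directly. Within the data shown here, the one measured step that bears on it has chloro in place of hydrogen on an aromatic carbon, and it is a 1.9-fold lower number from compound 1 to compound 2 (0.27 log units; within the scatter). As that step stays within the scatter, no step beyond the scatter is expected in this assay, and the data favour no clear direction. The expected step is a 1.2-fold higher number from compound 2 to compound 3 (0.06 log units; within the scatter). For compound 3 the estimated value is 36000 nM, with an expected range from 15000 nM to 80000 nM.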

Compound 3, concentration for 50% growth inhibition: 10000 nM
Compound 3: middle estimate off by 3.6-fold (0.56 log units), on the high side; measured number below the stated range.
By their numbers in this assay, from the lowest: compound 3; then compounds 2 and 1 (each within the scatter of the next).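

In this assay, going by these compounds alone, the exchange of 4-chlorophenyl for 3-chlorophenyl on a double-bonded chain carbon bound to a double-bonded chain carbon gives a 3.1-fold lower number from compound 2 to compound 3 (0.49 log units; beyond the scatter), the first evidence here that two compounds with the same atoms, joined differently, can be told apart on this read-out. Chloro in place of hydrogen on an aromatic carbon had stayed within the scatter on the way to compound 2, yet the same kind of change gives a 5.8-fold lower number from compound 1 to compound 3 (0.76 log units; beyond the scatter), so among these three compounds what chloro does depends on where it sits on the phenyl ring, and compound 3 now has the lowest number of the three. Nothing available accounts for this difference between the two chlorophenyl groups.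

As far as these compounds go, whether the lower number belongs to chloro itself or would also appear with 3-fluorophenyl, 3-bromophenyl or 3-methoxyphenyl remains open. The compounds shown also do not tell what 2-chlorophenyl would give at the same place, or whether two chloro groups on the phenyl ring would take the number lower still.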